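The source may hold more compounds than are shown below. What is called first, only, known or untested is meant among the compounds shown, and "the series" means these compounds.

Compound 1 `COc1ccc(OC)c(-c2nc(C(c3ccccc3)c3ccccc3)sc2CC(=O)O)c1` and compound 2 `NS(=O)(=O)c1cccc(-c2nc(C(c3ccc(F)cc3)c3ccc(F)cc3)sc2CC(=O)O)c1` share one core and differ in the group carried by the thiazole-like ring's aromatic carbon. In an in vitro functional assay on HEK285-7 cells for antagonist activity at prostaglandin D2 receptor 2 (Homo sapiens), read by BRET and beta-arrestin recruitment (on this read-out higher numbers stand for weaker inhibition and lower numbers for stronger inhibition), compound 1 gives only a limit, > 100000 nM. In this assay, within the data shown here, compound 2 gives 710 nM, the sole real number among the two values shown; the other sits at the limit of > 100000 nM in this assay, at which 1 of the 2 values shown sits. Compound 3 `Cc1cc(-c2nc(C(c3ccc(F)cc3)c3ccc(F)cc3)sc2CC(=O)O)ccn1` arises by 2-methylpyridin-4-yl in place of 3-sulfamoylphenyl on an aromatic carbon. Among the measured compounds shown here, no measured step joins such a pair, so the size is uncertain; a loss of potency beyond the usual scatter is expected, as a 4.2-fold higher number from compound 2 to compound 3 (0.63 log units; beyond the scatter). Compound 3 is therefore estimated at 3000 nM, within 700 nM to 15000 nM.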

Compound 3, half-maximal inhibitory concentration: 53 nM
Compound 3: middle estimate off by 57-fold (1.75 log units), on the high side, outside the stated range (below it).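

In this assay, the aromatic carbon bearing the aryl group proves sensitive to this change, with 2-methylpyridin-4-yl in place of 3-sulfamoylphenyl giving a 13-fold lower number from compound 2 to compound 3 (1.13 log units; beyond the scatter). Inhibition at this position therefore does not depend on the sulfamoyl group, since the entering group, though smaller, carries 0 hydrogen-bond donors. The data shown offer no explanation for the gain. As far as these compounds go, it remains open whether the ring nitrogen or the methyl group accounts for the step. A plain pyridin-4-yl or a 2-aminopyridin-4-yl at this position would separate these contributions.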